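The source may report more compounds than this note shows. Statements on the series, on what has been measured and on what is new or still open speak of the compounds shown alone.

Compound 1 `O=c1c2ccccc2c(-c2cccnc2)nn1CCSc1nccs1`: 97%
Compound 2 `NCCn1nc(-c2cccnc2)c2ccccc2c1=O`: 29%

In an assay on isolated protein (Oryctolagus cuniculus) with Thromboxane-A synthase (Homo sapiens) as the target, tested at 1 uM (on this read-out lower numbers stand for less inhibition and higher numbers for more inhibition at the one concentration tested (going by the name of the read-out)), compound 2 stands lower of the two measured compounds, the gap being a number 68 percentage points lower from compound 1 to compound 2 (beyond the scatter). Compound 3 `O=c1c2ccccc2c(-c2cccnc2)nn1CCNS(=O)(=O)c1ccccc1` differs from compound 2 by phenylsulfonyl in place of hydrogen on an amine nitrogen. For the measured compounds named here, only that one measured step bears on this change, and it shows that replacing a substituent on the chain by a bare amine lost a large amount of inhibition in this assay. Restoring a sizable group on the amine is therefore expected to raise inhibition, by about a number 41 percentage points higher from compound 2 to compound 3 (beyond the scatter). Compound 3 is estimated at 70%, within a range from 40% to 95%.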

Compound 3, a percentage reported as inhibition, at one concentration (the size of the read-out at that concentration, not a potency): 93%
Beside the measured number, compound 3's estimate is 23 percentage points below it; the measured number falls inside the stated range.
By their numbers in this assay, from the lowest: compound 2; then compounds 3 and 1 (each within the scatter of the next).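

In this assay the bare amine of compound 2 turns out not to be a dead end for this chain: placing phenylsulfonyl on the amine nitrogen gives a number 64 percentage points higher from compound 2 to compound 3 (beyond the scatter) as a large step. Inhibition therefore returns with a group quite unlike the (1,3-thiazol-2-yl)sulfanyl of compound 1, and compound 3 at 93% and compound 1 at 97% lie within the scatter of each other. No measurement here explains the size of this step.

Going by these compounds, whether the gain needs both the sulfonyl and the phenyl ring stays open. An acetyl or a benzyl group on the same amine nitrogen would help separate the two.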